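The source may report more compounds than this note shows. Statements on the series, on what has been measured and on what is new or still open speak of the compounds shown alone.

Measured compounds:
compound 1 `CC1=CS[C@@](OCC(F)(F)F)(c2ccc(Br)cc2)c2noc(=O)n21`, 19000 nM
compound 2 `CC1=CS[C@](OCC(F)(F)F)(c2ccc(Br)cc2)c2noc(=O)n21`, 12300 nM

In an ADME assay on ileum (Cavia porcellus) for antagonist activity (on this read-out higher numbers stand for weaker inhibition and lower numbers for stronger inhibition), compound 1 gives 19000 nM and compound 2 gives 12300 nM. Compound 2 has the lowest of the two numbers; its nearest neighbour is compound 1, separated by a 1.5-fold lower number from compound 1 to compound 2 (0.19 log units; within the scatter). The two compounds differ only in configuration as drawn (the fact that compounds 1 and 2 differ only in the configuration as drawn). Compound 3 `CC1=CSC(OCC(F)(F)F)(c2ccc(Br)cc2)c2noc(=O)n21` keeps the same atoms and bonds: the two compounds have the same atoms and bonds; at least one stereo element is drawn with a configuration in one of them and without one in the other: 1 of 1 stereo elements differ; a stereocentre at a saturated ring carbon is drawn R in compound 2 and without a configuration in compound 3. Going by the values given here, the single measured step that bears on this change is a 1.5-fold lower number from compound 1 to compound 2 (0.19 log units; within the scatter), which lies within the scatter, so the two drawn configurations give numbers that are not distinguishable in this assay. Compound 3 is expected to sit between these two numbers in this assay, which means a step of a 1.2-fold higher number from compound 2 to compound 3 (0.09 log units; within the scatter), expected to stay within the scatter. Compound 3 is estimated at 15000 nM, with a range from 8000 nM to 28000 nM.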

Compound 3, half-maximal inhibitory concentration: 25900 nM
Beside the measured number, compound 3's estimate is 1.7-fold (0.24 log units) below it; measured number inside the range.
By their numbers in this assay, from the lowest: compounds 2, 1 and 3 (each within the scatter of the next, the first and the last beyond it).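

In this assay, the step of a 2.1-fold higher number from compound 2 to compound 3 (0.32 log units; beyond the scatter) is the only one among these three compounds that passes the scatter, and it does so modestly. The step of a 1.4-fold higher number from compound 1 to compound 3 (0.13 log units; within the scatter) does not separate that pair, so the configuration at the saturated ring carbon gives no clear separation across the set, only one edge case against the R drawing. Both steps involve no change in atoms or bonds, so any reading of them rests on this stereocentre alone: the fact that one of compounds 2 and 3 is drawn with a defined configuration and the other without, at the place where they differ

The data do not say what compound 3 contains at this stereocentre, so its number cannot be read as that of a mixture of compound 1 and compound 2. On these data alone, whether an amine or a carboxylic acid on the shared core would move the number in this assay further than this stereocentre does remains open.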